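Chloro for Bromo at the Ether-Bearing Ring of Compound 1

A few compounds are considered here, and "the series" means these few. Any claim that something is new, unique, unknown or untested is made for them only; others in the source may bear on it.

Among the compounds with values here, compound 1 `Brc1ccccc1OCc1nc2ccccc2[nH]1` is one of two compounds measured in an ADME assay on microsomes from liver for inhibition of cytochrome P450 2B1 (Rattus norvegicus); a lower number here means a stronger inhibitor, a higher number a weaker inhibitor; in this assay compound 1 gives 12000 nM, and the only other number lies within the scatter of it. That neighbour, compound 2 `Brc1ccc(OCc2nc3ccccc3[nH]2)c(Br)c1`, gives 11000 nM in this assay, so the step of a 1.1-fold lower number from compound 1 to compound 2 (0.04 log units; within the scatter) is within the scatter. Compound 3 `Clc1ccccc1OCc1nc2ccccc2[nH]1` differs from compound 1 by chloro in place of bromo on an aromatic carbon. Within the data shown here, no measured step swaps one halogen for another; the single step known, bromo in place of hydrogen, moved the number little. Compound 3 is therefore expected to sit close to compound 1, with an expected step of no change at the digits printed from compound 1 to compound 3 (within the scatter). The estimate for compound 3 is 12000 nM, within 5000 nM to 30000 nM.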

Compound 3, half-maximal inhibitory concentration: 26900 nM
Compound 3: the middle estimate sits 2.2-fold (0.35 log units) below what was measured, within the range that was stated.
By their numbers in this assay, from the lowest: compounds 2 and 1 (each within the scatter of the next); then compound 3.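

In this assay, chloro in place of bromo on this aromatic carbon gives a 2.2-fold higher number from compound 1 to compound 3 (0.35 log units; beyond the scatter), so this position responds to which halogen it carries. The only earlier step, adding bromo at another aromatic carbon, stayed within the scatter, and this is the first change shown to move the number beyond it. Nothing available accounts for this shift. On these data alone, whether methyl, methoxy or trifluoromethyl on this carbon would raise or lower the number remains open. So does whether the same halogen swap would act alike with the second bromo of compound 2 present.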